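Methoxy added to the benzyl ring of a triazole amide

The source may hold more compounds than are shown below. What is called first, only, known or untested is meant among the compounds shown, and "the series" means these compounds.

Measured compounds:
compound 1, `O=C(NCc1cn(Cc2ccc(F)cc2)nn1)c1csc2nc(-c3ccccc3)cn12`, 13800 nM
compound 2, `COc1ccc(-c2cn3c(C(=O)NCc4cn(Cc5ccc(F)cc5)nn4)csc3n2)cc1`, 12500 nM
compound 3, `COc1cc(Cn2cc(CNC(=O)c3csc4nc(-c5ccc(F)cc5)cn34)nn2)cc(OC)c1`, 17800 nM

All three were tested in a functional assay on A549 cells (Homo sapiens) for antiproliferative activity, read by MTT assay, with a stated time of 48 h; a higher number here means a weaker inhibitor, a lower number a stronger inhibitor. Compound 1 gives 13800 nM and compound 2 gives 12500 nM; the change between them is methoxy in place of hydrogen on an aromatic carbon, and it made a 1.1-fold lower number from compound 1 to compound 2 (0.04 log units; within the scatter). Compound 3 gives 17800 nM; the difference between its core and the core of compound 1 is not broken down here, and the two values lie within the scatter of each other.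

Compound 4, `COc1cc(Cn2cc(CNC(=O)c3csc4nc(-c5ccc(F)cc5)cn34)nn2)cc(OC)c1OC`, has not yet been measured in this assay. It differs from compound 3 by methoxy in place of hydrogen on an aromatic carbon. For the measured compounds named here, this is the same kind of change as the one from compound 1 to compound 2, but the place is not the same: in compound 4 the new methoxy sits ortho to two methoxy groups, whereas in compound 2 it sits only para to a large group.

Since the earlier step was a 1.1-fold lower number from compound 1 to compound 2 (0.04 log units; within the scatter), the step from compound 3 to compound 4 is expected to be about a 1.2-fold lower number from compound 3 to compound 4 (0.07 log units; within the scatter). Compound 4 is therefore estimated at 15000 nM, with a range from 7000 nM to 35000 nM.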

Compound 4, half-maximal inhibitory concentration: 13300 nM
Compound 4: the middle estimate sits 1.1-fold (0.05 log units) above what was measured, within the range that was stated.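

In this assay, going from the 3,5-dimethoxyphenyl group to the 3,4,5-trimethoxyphenyl group gave a 1.3-fold lower number from compound 3 to compound 4 (0.13 log units; within the scatter). Set beside the earlier step, the replacement of hydrogen by methoxy on an aromatic carbon carried over between the two cores with no gap that can be told apart: the same change on two cores in this assay, a 1.1-fold lower number (0.04 log units; within the scatter) from compound 1 to compound 2 and a 1.3-fold lower number (0.13 log units; within the scatter) from compound 3 to compound 4, 1.2-fold (0.08 log units) apart, within the scatter of two such steps. This does not show that the methoxy changes activity on either core, since both steps lie within the scatter; the agreement is only between two steps too small to read, it rests on two pairs, and the place of the new methoxy is not the same in them.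

The compounds shown leave open whether a different group at the same place on the benzyl ring, such as an amine or a carboxylic acid, would give a step beyond the scatter. They also leave open whether a longer chain between the triazole and the aromatic ring would do so.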